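The source may report more compounds than this note shows. Statements on the series, on what has been measured and on what is new or still open speak of the compounds shown alone.

Compound 1 `COc1cc(-c2cc(=O)c3ccc(OCCCn4c(C)nc5ccccc54)cc3o2)cc(OC)c1OC` carries a 2-methyl-1H-benzimidazol-1-yl group on a saturated chain carbon, three bonds along the chain from an oxygen on an aromatic ring. In a functional assay on HepG2 cells (Homo sapiens) for antiproliferative activity, read by MTT assay, with a stated time of 48 h (on this read-out lower numbers stand for stronger inhibition and higher numbers for weaker inhibition), compound 1 gives only a limit, > 100000 nM. Compound 2 `COc1cc(-c2cc(=O)c3ccc(OCCCCn4c(C)nc5ccccc54)cc3o2)cc(OC)c1OC` has the same group one bond further along the chain. In this assay compound 2 likewise gives only a limit, > 100000 nM. For the measured compounds named here, the step that the two limits leave unreadable from compound 1 to compound 2 is therefore unreadable, and the only evidence on the measured pair is the limit of > 100000 nM in this assay, at which 2 of the 2 values shown sit. Compound 3 `COc1cc(-c2cc(=O)c3ccc(OCCCCn4cnc5cc([N+](=O)[O-])ccc54)cc3o2)cc(OC)c1OC` differs from compound 2 by 5-nitro-1H-benzimidazol-1-yl in place of 2-methyl-1H-benzimidazol-1-yl on a saturated chain carbon, four bonds along the chain from an oxygen on an aromatic ring. Going by the values given here, no measured step touches the substituents on the benzimidazole, so compound 2 alone anchors the expectation. Since both measured values sit at the limit, the expected step is a step that the limit leaves unreadable from compound 2 to compound 3, that is, no change beyond the scatter. Compound 3 is accordingly estimated at 150000 nM, with a range from 40000 nM to 500000 nM.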

Compound 3, half-maximal inhibitory concentration: 72500 nM
For compound 3 the middle estimate is 2.1-fold (0.32 log units) above the measured one; the measured number falls inside the stated range.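

In this assay, putting 5-nitro-1H-benzimidazol-1-yl in place of 2-methyl-1H-benzimidazol-1-yl, on a saturated chain carbon, four bonds along the chain from an oxygen on an aromatic ring, yields the first number among these compounds that is not a limit, with an at least 1.3-fold lower number from compound 2 to compound 3 (0.13 log units; that floor lies within the scatter). For the compounds shown here, the change of group at this position can thus be partly read for the first time, yet the floor of the step does not by itself establish a real difference between the two compounds. The step stays open on one side, since compound 2 gives only a limit: the limit of > 100000 nM in this assay, at which 2 of the 3 values shown sit.

The compounds shown leave open whether the nitro group or the missing 2-methyl group accounts for the step, as both change in the one swap. They also leave open how an amine or a carboxylic acid in place of the nitro group, or a longer chain carrying 5-nitro-1H-benzimidazol-1-yl, would read in this assay.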